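Ester tail of compound 2 with a morpholine amide

A few compounds are considered here, and "the series" means these few. Any claim that something is new, unique, unknown or untested is made for them only; others in the source may bear on it.

Measured so far:
- compound 1, `CCOc1cc(NC(=O)C2(NC(=O)c3ccc4c(C5CCCC5)c(-c5ncc(Cl)cn5)n(C)c4c3)CCC2)ccc1/C=C/C(=O)N[C@@H](CC(=O)O)C(N)=O`: > 5 h
- compound 2, `CCOc1cc(NC(=O)C2(NC(=O)c3ccc4c(C5CCCC5)c(-c5ncc(Cl)cn5)n(C)c4c3)CCC2)ccc1/C=C/C(=O)OCC(N)=O`: 0.6 h

Two compounds share one core and differ only in the tail attached to the carbonyl carbon at the end of the chain. In an ADME assay on stomach for pharmacokinetics, in simulated gastric fluid (on this read-out higher numbers stand for a longer-lived compound and lower numbers for a shorter-lived compound), compound 1 gives > 5 h, which is a limit of the assay and not a number. Among the measured compounds shown here, compound 2 gives 0.6 h in this assay, the only actual number among the two values, so compound 2 stands as the shorter-lived of the pair. The step of an at least 8.3-fold lower number from compound 1 to compound 2 (0.92 log units; beyond the scatter) shows that the swap from the amino-linked tail to the oxygen-linked tail shortened the half-life well beyond the scatter.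

Compound 3, `CCOc1cc(NC(=O)C2(NC(=O)c3ccc4c(C5CCCC5)c(-c5ncc(Cl)cn5)n(C)c4c3)CCC2)ccc1/C=C/C(=O)OCC(=O)N1CCOCC1`, keeps the oxygen-linked tail of compound 2 and changes only its far end: morpholin-4-yl in place of amino on a carbonyl carbon. For the measured compounds named here, no measured step touches this part of the molecule; the one known step, an at least 8.3-fold lower number from compound 1 to compound 2 (0.92 log units; beyond the scatter), concerns the link to the chain, which compound 3 retains unchanged from compound 2. With nothing pointing either way, the expected step of a 1.2-fold higher number from compound 2 to compound 3 (0.07 log units; within the scatter) is none beyond the scatter. Compound 3 is therefore estimated at 0.7 h in this assay, within a range of 0.3 h to 1.8 h.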

Compound 3, half-life: 0.85 h
For compound 3 the middle estimate is 1.2-fold (0.08 log units) below the measured one; the range from low to high includes it.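

In this assay, putting morpholin-4-yl in place of amino on a carbonyl carbon gives a 1.4-fold higher number from compound 2 to compound 3 (0.15 log units; within the scatter), so this site accepts a six-membered ring and the loss of the hydrogen-bond donor with no change that can be told from the scatter. Among the compounds shown here, the larger difference remains the one that compound 1 showed against compound 2, and it returns with the new tail as an at least 5.8-fold lower number from compound 1 to compound 3 (0.76 log units; beyond the scatter), so both oxygen-linked tails shown sit beyond the scatter from the amino-linked tail of compound 1. The true size of that step stays unknown, as the value of compound 1 is a limit of the assay and not a number: the limit of > 5 h in this assay, at which 1 of the 3 values shown sits.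

The tail of compound 1 differs from the other two both in the atom that links it to the carbonyl carbon and in what it carries further out, including a carboxylic acid, so the compounds shown cannot say which of these parts matters. Also open, on these data alone, is whether a dimethylamino group or a piperazine on the carbonyl carbon of the oxygen-linked tail would stay as close to compound 2 as morpholin-4-yl does, or whether a carboxylic acid there would move the half-life beyond the scatter.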